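This account rests on a few compounds, and the source may have more. Where it says the series, first, only, none or still open, it means among the compounds named here.

Measured in an ADME assay on a cell-free system (plasma, Rattus norvegicus) for metabolic stability, read by LC-MS, with a stated time of 60 min, tested at 100 uM; on this read-out lower numbers stand for a less stable compound and higher numbers for a more stable compound:
Compound 1 `Cc1cc(C(=O)O)ccc1OCCCCOc1ccc(C(=O)CC(C)C)c(O)c1C`: 100%
Compound 2 `COc1cc(C(=O)O)ccc1OCCCCOc1ccc(C(=O)CC(C)C)c(O)c1C`: 99%
Compound 3 `Cc1ccc(C(=O)O)cc1OCCCCOc1ccc(C(=O)CC(C)C)c(O)c1C`: 96%

These three numbers cannot be told apart, so compound 1 stands level with the other two. Compound 4 `Cc1cc(C(=O)O)ccc1OCCCCOc1ccc(C(=O)CC2CCCC2)c(O)c1C` differs from compound 1 by cyclopentyl in place of isopropyl on a saturated chain carbon bound to a carbonyl carbon. Two measured steps offer only indirect guidance, since both change other places: a number 1 percentage points lower from compound 1 to compound 2 (within the scatter) and a number 4 percentage points lower from compound 1 to compound 3 (within the scatter). Neither moved the number beyond the scatter, so no clear change is expected here. The expected step is a number 3 percentage points lower from compound 1 to compound 4 (within the scatter). For compound 4 the estimated value is 97%, with an expected range of 88% to 100%.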

Compound 4, percent of the compound remaining: 99%
For compound 4 the middle estimate is 2 percentage points below the measured one; low and high end bracket the measured number.
By their numbers in this assay, from the lowest: compounds 3, 2, 4 and 1 (each within the scatter of the next).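

In this assay, cyclopentyl in place of isopropyl on a saturated chain carbon bound to a carbonyl carbon gives a number 1 percentage points lower from compound 1 to compound 4 (within the scatter) and so brings no clear change. Among these compounds, the earlier steps changed other places, so this is the first sign that this place accepts a larger all-carbon group containing a ring. From the compounds shown here alone, whether an amine, a carboxylic acid or a longer chain would be accepted here as well remains open. No available measurement offers an explanation for this result.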